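The compounds below may be only part of what the source reports. "The series", "measured", "known", "first", "only" and "open" are said of these compounds alone.

Compound 1 `CCCCCCCCCCCCCCCCO[C@H]1O[C@H](COCC(CO)(CO)COS(=O)(=O)O)[C@@H](O)[C@H](O)[C@H]1NC(=O)CCCC` carries a hexadecyl ether on one side of its core and a branched polyol bearing a sulfate on the other. In a functional assay on U-373MG ATCC cells (Homo sapiens), read by thymidine incorporation (a lower number here means a stronger inhibitor, a higher number a weaker inhibitor), compound 1 gives 3.2 uM. Among the compounds with values here, this is the only number among the two values shown; the other is a limit, (the limit of > 50 uM in this assay, at which 1 of the 2 values shown sits). Within the data shown here, compound 2 `CCCCC(=O)N[C@H]1[C@@H](OCCc2ccccc2)O[C@H](COCC(CO)(CO)CO)[C@@H](O)[C@@H]1O` differs from compound 1 in several places at once, so no single step joins the pair. In this assay compound 2 reaches only the limit of > 50 uM. Compound 3 `CCCCCCCCCCCCCCCCO[C@H]1O[C@H](COCC(O)CO)[C@@H](O)[C@H](O)[C@H]1NC(=O)CCCC` has not yet been measured. It differs from compound 1 in one place: 1,2-dihydroxyethyl in place of 2-hydroxy-1-(hydroxymethyl)-1-((sulfooxy)methyl)ethyl on a saturated chain carbon bound to an oxygen on a saturated carbon. Among the measured compounds shown here, no measured pair isolates this change, so the expectation rests on compound 1 alone, and a step toward weaker inhibition that goes beyond the scatter is expected, a 3.8-fold higher number from compound 1 to compound 3 (0.57 log units; beyond the scatter). For compound 3 the estimate in this assay is 12 uM, with a range from 3 uM to 50 uM.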

Compound 3, concentration for 50% inhibition: 4.6 uM
For compound 3 the middle estimate is 2.6-fold (0.42 log units) above the measured one; measured number inside the range.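

Replacing 2-hydroxy-1-(hydroxymethyl)-1-((sulfooxy)methyl)ethyl with 1,2-dihydroxyethyl on a saturated chain carbon bound to an oxygen on a saturated carbon gives a 1.4-fold higher number from compound 1 to compound 3 (0.16 log units; within the scatter) in this assay. Within the data shown here, the sulfate and the branched polyol carrying it can thus leave this position without a step beyond the scatter, which the earlier compounds, differing in several places at once, could not show. Nothing in the data shown gives a cause for this result.

Still open, going by these compounds, is how this position would respond to a different kind of group, such as an amine or a carboxylic acid in place of the 1,2-dihydroxyethyl. Also open is how a shorter chain in place of the hexadecyl ether would read in this assay; no pair shown isolates that ether.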